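From 3,4-dichlorophenyl to ethyl on the shared core

The compounds below may be only part of what the source reports. "The series", "measured", "known", "first", "only" and "open" are said of these compounds alone.

Compound 1 `O=C(/C=C/c1ccc(O)c(O)c1)N1CCN(c2ccccc2Cl)CC1` gives 1.44 ug/mL
Compound 2 `O=C(/C=C/c1ccc(O)c(O)c1)N1CCN(c2cccc(Cl)c2)CC1` gives 1.29 ug/mL
Compound 3 `O=C(/C=C/c1ccc(O)c(O)c1)N1CCN(c2ccc(Cl)c(Cl)c2)CC1` gives 1.74 ug/mL

All three values come from a functional assay on A549 cells (Homo sapiens) for antiproliferative activity, read by MTT assay, with a stated time of 48 h (a lower number here means a stronger inhibitor, a higher number a weaker inhibitor), and the compounds differ only in the chloro groups on the phenyl group. Compound 3 at 1.74 ug/mL cannot be told apart from the other two. The steps that reach it are a 1.2-fold higher number from compound 1 to compound 3 (0.08 log units; within the scatter) and a 1.3-fold higher number from compound 2 to compound 3 (0.13 log units; within the scatter) while the remaining step is a 1.1-fold lower number from compound 1 to compound 2 (0.05 log units; within the scatter) and so the three form one flat group.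

Compound 4 `CCN1CCN(C(=O)/C=C/c2ccc(O)c(O)c2)CC1` departs from this group. Its difference from compound 3 is ethyl in place of 3,4-dichlorophenyl on an amine nitrogen in a ring with ethyl in place of 3,4-dichlorophenyl on an amine nitrogen in a ring. The measured steps bear on this only in part. Each of them keeps the phenyl group, and none shows what happens when that ring is removed. The flatness of a 1.3-fold higher number from compound 2 to compound 3 (0.13 log units; within the scatter) therefore sets no firm size for the new step, which is a far larger change than any measured so far. A move to a higher number in this assay is expected, though with wide uncertainty. The estimated step is a 2.6-fold higher number from compound 3 to compound 4 (0.41 log units; beyond the scatter) and it may prove smaller or larger. Compound 4 is expected at 4.5 ug/mL with an estimated range of 1.5 ug/mL to 20 ug/mL.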

Compound 4, half-maximal inhibitory concentration: 6.54 ug/mL
Beside the measured number, compound 4's estimate is 1.5-fold (0.16 log units) below it; the range from low to high includes it.
By their numbers in this assay, from the lowest: compounds 2, 1 and 3 (each within the scatter of the next); then compound 4.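

Within the data shown here, compound 4 is the first change on the amine nitrogen in a ring that this assay clearly registers: the chloro groups on the phenyl group gave one flat group, whereas ethyl in place of the chlorinated phenyl groups gives a 3.8-fold higher number from compound 3 to compound 4 (0.58 log units; beyond the scatter) and a 5.1-fold higher number from compound 2 to compound 4 (0.70 log units; beyond the scatter) and a 4.5-fold higher number from compound 1 to compound 4 (0.66 log units; beyond the scatter) as the three steps. Among these four compounds, compound 4 is therefore the weakest inhibitor, and this position proves sensitive to replacing the whole substituent even though it showed no measurable response to the chloro changes. The step removes the aromatic ring and the chlorine atoms together and also shrinks the group from 8 heavy atoms to 2, and no measurement given here accounts for the shift.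

The compounds shown leave open whether the aromatic ring itself matters or only the size of the group, a question that an unsubstituted phenyl, a benzyl group or a longer alkyl chain such as butyl on the same nitrogen would help to settle. On these data alone, it also remains open how a group carrying a free amine or a carboxylic acid would behave at this position.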